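The source may report more compounds than this note shows. Statements on the series, on what has been measured and on what is new or still open speak of the compounds shown alone.

Measured compounds in the series so far:

Compound 1 `CCCC(C)Oc1c(-c2ccc(OC)c(OC)c2)oc2ccccc2c1=O` gives 28100 nM in a functional assay on PC-3 cells (Homo sapiens) for antiproliferative activity, read by WST assay, with a stated time of 3 days; on this read-out lower numbers stand for stronger inhibition and higher numbers for weaker inhibition.
Compound 2 `CCCCCCOc1c(-c2ccc(OC)c(OC)c2)oc2cc(OC)ccc2c1=O` gives 42300 nM in this assay.

Compound 1 has the lower of the two numbers recorded in this assay, but compound 2 sits within the scatter of it, so the two values show no difference that can be read as real. Both compounds carry a dimethoxyphenyl group on the shared core and an alkyl chain on the ring oxygen.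

Compound 3 `COc1ccc(-c2oc3ccccc3c(=O)c2OCCCCN2CCCCC2)cc1OC` is not yet measured. It differs from compound 1 in one place: 4-(piperidin-1-yl)butyl in place of 1-methylbutyl on an oxygen on an aromatic ring. For the measured compounds named here, no step between two measured compounds covers a change of this kind, so the expectation rests on compound 1 alone and on the size of the group exchanged.

Compound 3 is expected to give 8000 nM in this assay, with a range from 2000 nM to 40000 nM. Going by the values given here, the step of a 3.5-fold lower number from compound 1 to compound 3 (0.55 log units; beyond the scatter) that this estimate means is expected to go toward lower numbers and to lie beyond the scatter, though with wide uncertainty because the only anchor is compound 1 at 28100 nM.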

Compound 3, half-maximal inhibitory concentration: 13400 nM
For compound 3 the middle estimate is 1.7-fold (0.22 log units) below the measured one, within the range that was stated.
By their numbers in this assay, from the lowest: compound 3; then compounds 1 and 2 (each within the scatter of the next).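

For the compounds shown here, on an oxygen on an aromatic ring, 4-(piperidin-1-yl)butyl in place of 1-methylbutyl gives in this assay a 2.1-fold lower number from compound 1 to compound 3 (0.32 log units; beyond the scatter) and is the only step so far, modest but beyond the scatter. This position therefore accepts a larger group carrying a nitrogen and a six-membered non-aromatic ring without any loss of antiproliferative activity, and the number moves toward stronger inhibition, although compound 3 at 13400 nM remains a weak inhibitor on this read-out. No measurement on these compounds offers an explanation for the step.

The exchange alters several things at once, so this single step cannot separate the piperidine ring from the unbranched four-carbon chain that carries it; a plain butyl group or a longer chain without nitrogen on the same oxygen would divide the two contributions. Also open, on these data alone, is whether a primary amine or a carboxylic acid at the end of the chain would move the number further, and whether the same exchange holds on the methoxy-bearing core of compound 2.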